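The compounds below may be only part of what the source reports. "The series", "measured", "known", "first", "only" and "open" are said of these compounds alone.

Compound 2 `CC(c1cc2cc(-c3cnn(C)c3)cnc2cc1F)n1nnc2ncc(-c3ccc(C(N)=O)c(F)c3)nc21` is a very strong inhibitor in a functional assay on NCI-H1993 cells (Homo sapiens) for inhibition, read by CCK-8 assay, with a stated time of 72 h (on this read-out higher numbers stand for weaker inhibition and lower numbers for stronger inhibition), where compound 2 gives 0.9 nM. Its closest measured neighbour is compound 1 `CC(c1ccc2ncc(-c3cnn(C)c3)cc2c1)n1nnc2ncc(-c3ccc(C(N)=O)c(F)c3)nc21`, which in this assay gives 0.9 nM. The only measured step, no change at the digits printed from compound 1 to compound 2 (within the scatter), came from a fluoro in place of hydrogen on an aromatic carbon, so the two compounds are level at the digits shown.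

Compound 3 `CNC(=O)c1ccc(-c2cnc3nnn(C(C)c4cc5cc(-c6cnn(C)c6)cnc5cc4F)c3n2)cc1F` differs from compound 2 in one place: methyl in place of hydrogen on an amide-type nitrogen, that is, carbamoyl becomes methylcarbamoyl. Within the data shown here, no measured step touches this amide-type nitrogen, and the fluoro step from compound 1 to compound 2 changes a different part of the molecule, so it offers little guidance here. With compound 2 already near the strong end of the scale, the expected step of a 1.7-fold higher number from compound 2 to compound 3 (0.22 log units; within the scatter) is small, if any. Compound 3 is therefore estimated at 1.5 nM, with a range of 0.5 nM to 5 nM.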

Compound 3, half-maximal inhibitory concentration: 1.1 nM
Beside the measured number, compound 3's estimate is 1.4-fold (0.13 log units) above it, and the stated range covers the measured number.
By their numbers in this assay, from the lowest: compounds 1, 2 and 3 (each within the scatter of the next).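

Methyl in place of hydrogen on the amide-type nitrogen gives a 1.2-fold higher number from compound 2 to compound 3 (0.09 log units; within the scatter) in this assay, and this is the only measured step at that nitrogen. Carbamoyl and methylcarbamoyl therefore cannot be told apart on this read-out, so at least one amide hydrogen can be replaced by methyl with the number staying at the strong end of the scale. The information shown offers no explanation for this result.

It remains open whether this nitrogen would also accept an ethyl group, a longer chain or a chain ending in an amine, as methyl is the only group shown there. It is also unknown whether methyl would behave the same way in compound 1, which has hydrogen where compound 2 carries its fluoro.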